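A nitrophenyl sulfonyl group follows a trimethylphenyl one

A few compounds are considered here, and "the series" means these few. Any claim that something is new, unique, unknown or untested is made for them only; others in the source may bear on it.

Compound 1 `COC(=O)c1ccc(C2SCC(=O)N2c2ccc(N3CCN(Cc4ccc(Cl)c(Cl)c4)CC3)cn2)c(OC)c1` and compound 2 `COC(=O)c1ccc(C2SCC(=O)N2c2ccc(N3CCN(S(=O)(=O)c4c(C)cc(C)cc4C)CC3)cn2)c(OC)c1` share one core and differ only in the group on an amine nitrogen in a ring. In a functional assay on Jurkat cells (Homo sapiens) for antiproliferative activity, read by MTT assay and trypan blue exclusion, with a stated time of 72 h (on this read-out lower numbers stand for stronger inhibition and higher numbers for weaker inhibition), compound 1 gives 61000 nM. Compound 2 reaches only the limit of this assay, > 100000 nM, which is a bound rather than a number. Going by the values given here, the single measured step, an at least 1.6-fold higher number from compound 1 to compound 2 (0.21 log units; that floor lies within the scatter), thus rests on a floor, and the limit of > 100000 nM in this assay, at which 1 of the 2 values shown sits, is where compound 2 stands. Compound 3 `COC(=O)c1ccc(C2SCC(=O)N2c2ccc(N3CCN(S(=O)(=O)c4ccc([N+](=O)[O-])cc4)CC3)cn2)c(OC)c1` is the next change from compound 2: 4-nitrophenyl in place of 2,4,6-trimethylphenyl on a sulfonyl sulfur. Among the compounds with values here, no measured step touches the aryl group on the sulfonyl sulfur, so the one step known offers no direction for this change; the writer expects, in this assay, a step of about a number no higher from compound 2 to compound 3 (the limit leaves the size open), that is, none beyond the scatter, with a fair chance of another limit. For compound 3 the estimate in this assay is 100000 nM, between 40000 nM and 250000 nM.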

Compound 3, half-maximal inhibitory concentration: 54000 nM
The estimate for compound 3 lay 1.9-fold (0.27 log units) above the measured number; the measured number falls inside the stated range.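

In this assay, the change of aryl group on the sulfonyl sulfur gives an at least 1.8-fold lower number from compound 2 to compound 3 (0.26 log units; that floor lies within the scatter), so a sulfonyl group on this nitrogen now has a measured number and not only a limit. From the compounds shown here alone, the true size of this step remains unknown, since it rests on compound 2, whose value is a limit: the limit of > 100000 nM in this assay, at which 1 of the 3 values shown sits. Set against the 3,4-dichlorobenzyl group, the (4-nitrophenyl)sulfonyl group gives a 1.1-fold lower number from compound 1 to compound 3 (0.05 log units; within the scatter), so compound 1 and compound 3 cannot be ordered in this assay.

Going by these compounds, it remains open whether a 4-aminophenyl or 4-methoxyphenyl group on the sulfonyl sulfur would give a step beyond the scatter. The same question stands for an acetyl group on the amine nitrogen in a ring.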